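This account rests on a few compounds, and the source may have more. Where it says the series, first, only, none or still open, it means among the compounds named here.

Of the compounds shown here, three sharing one core have been measured in a physicochemical assay for lipophilicity, measured as octanol-water partition; on this read-out lower numbers stand for lower lipophilicity and higher numbers for higher lipophilicity. Compound 1 `CC(C)[C@@H]1CC[C@@H](C)C[C@H]1OC(=O)c1ccc(Cl)cc1Cl` gives 5.86, compound 2 `CC(C)[C@@H]1CC[C@@H](C)C[C@H]1OC(=O)/C=C/c1cccc([N+](=O)[O-])c1` gives 5.18, and compound 3 `CC(C)[C@@H]1CC[C@@H](C)C[C@H]1OC(=O)c1ccc(Cl)cc1` gives 5.34. The number for compound 3 thus lies within the scatter of the number for compound 2, and clearly under the number for compound 1.

Compound 4 `Cc1ccc(C(=O)O[C@@H]2C[C@H](C)CC[C@H]2C(C)C)cc1` departs from compound 3 in one place: methyl in place of chloro on an aromatic carbon. In short, it has methyl in place of chloro on an aromatic carbon. Going by the values given here, one measured step bears on this: a number 0.52 log units lower from compound 1 to compound 3 (beyond the scatter), where hydrogen takes the place of chloro on an aromatic carbon. Here a methyl, not a hydrogen, enters, and no measured step exchanges chloro for methyl, so that step is only a loose guide. No step beyond the scatter is therefore expected in this assay, and any drift is expected to be slight. The estimated change is a number 0.09 log units lower from compound 3 to compound 4 (within the scatter). For compound 4 the expected value is 5.25, with an estimated range from 4.9 to 5.6.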

Compound 4, partition coefficient: 5.29
Compound 4: middle estimate off by 0.04 log units, on the low side; low and high end bracket the measured number.
By their numbers in this assay, from the lowest: compounds 2, 4 and 3 (each within the scatter of the next); then compound 1.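

In this assay, exchanging chloro for methyl on an aromatic carbon, para to a large group, gives a number 0.05 log units lower from compound 3 to compound 4 (within the scatter), so at this position one group can replace the other with no step beyond the scatter. The earlier step, a number 0.52 log units lower from compound 1 to compound 3 (beyond the scatter), involved a second chloro at another place on the ring and brought in a hydrogen, so it said nothing directly about this position, and the new pair is the only direct reading of it shown here. Nothing at hand accounts for this result.

From the compounds shown here alone, whether an amine, a carboxylic acid or a longer chain at this same place would also stay within the scatter remains open. So does whether methyl in place of the other chloro of compound 1 would behave as it does here, since this single exchange cannot speak for that place.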